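A few compounds are considered here, and "the series" means these few. Any claim that something is new, unique, unknown or untested is made for them only; others in the source may bear on it.

Three measured compounds share one core, all tested in a functional assay on the whole organism (strain Wistar) for inhibition, with Rattus norvegicus as the target, read by paw edema, with stated times of 30 min and 5 h, at a dose of 0.05 mmol/kg by the oral route; on this read-out lower numbers stand for less inhibition and higher numbers for more inhibition at the one dose given (going by the name of the read-out). Compound 1 `CS(=O)(=O)c1ccc(N2N=C(c3ccc(-c4ccccc4)cc3)CCC2=O)cc1` gives 21% in this assay. Compound 2 `CS(=O)(=O)c1ccc(N2N=C(c3ccc(Cl)c(Cl)c3)CCC2=O)cc1` gives 34.2% in this assay. Compound 3 `Cc1ccc(O)c(C2=NN(c3ccc(S(C)(=O)=O)cc3)C(=O)CC2)c1` gives 86.8% in this assay, the highest of the three numbers and beyond the scatter from both others; the nearest is compound 2, the furthest compound 1. Among the compounds with values here, the single one-place step among the measured compounds, a number 52.6 percentage points higher from compound 2 to compound 3 (beyond the scatter), shows the 2-hydroxy-5-methylphenyl on the carbon with a double bond to nitrogen carrying a large gain over 3,4-dichlorophenyl at that carbon.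

Compound 4 `CS(=O)(=O)c1ccc(N2N=C(c3ccc(F)cc3)CCC2=O)cc1` is not yet measured. It differs from compound 3 at that same carbon: 4-fluorophenyl in place of 2-hydroxy-5-methylphenyl on a carbon with a double bond to nitrogen. The step that bears on this is a number 52.6 percentage points higher from compound 2 to compound 3 (beyond the scatter), read in reverse: the 2-hydroxy-5-methylphenyl leaves and a phenyl bearing no hydrogen-bond donor enters. Compounds 1 and 2, each with such a phenyl at that carbon, both sit far below compound 3, so a large fall is expected. The step of a number 54.8 percentage points lower from compound 3 to compound 4 (beyond the scatter) is therefore expected to be downward and beyond the scatter, landing near compounds 1 and 2. Compound 4 is estimated at 32%, within 15% to 55% in this assay.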

Compound 4, a percentage reported as inhibition, in the whole organism at one dose (the size of the read-out at that dose, not a potency): 73.6%
The estimate for compound 4 lay 41.6 percentage points below the measured number; measured number above the stated range.
By their numbers in this assay, from the lowest: compound 1; then compound 2; then compound 4; then compound 3.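

In this assay the 4-fluorophenyl, with 0 hydrogen-bond donors, keeps most of the number at this carbon, with a number 13.2 percentage points lower from compound 3 to compound 4 (beyond the scatter) as a modest step, so a hydrogen-bond donor on the phenyl is not needed for a high number in this short series. The phenyls without a donor also differ widely among themselves, with a number 39.4 percentage points higher from compound 2 to compound 4 (beyond the scatter) and a number 52.6 percentage points higher from compound 1 to compound 4 (beyond the scatter) both large, so the earlier gap between 3,4-dichlorophenyl and 2-hydroxy-5-methylphenyl cannot be read as a donor effect alone, and the low numbers of compound 1 and compound 2 now look tied to those particular phenyls. Nothing at hand gives a reason for any of these steps.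

Still open is whether the hydroxy or the methyl of the 2-hydroxy-5-methylphenyl accounts for the margin of compound 3 over compound 4, since the compounds shown change both together. Also open, going by these compounds, is how an amine, a carboxylic acid or a short alkoxy chain in place of the fluoro would fare at this carbon, and whether any such phenyl would hold up at doses other than the single one given.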